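From Methyl to Benzyl on the Ring Nitrogen

The source may report more compounds than this note shows. Statements on the series, on what has been measured and on what is new or still open speak of the compounds shown alone.

Measured so far:
compound 1, `COC(=O)/C=C/c1ccc2c(c1)C(=O)C(=O)N2`: 200 nM
compound 2, `COC(=O)/C=C/c1ccc2c(c1)C(=O)C(=O)N2C`: 250 nM

In a functional assay on Jurkat cells (Homo sapiens) for antiproliferative activity, read by MTT assay, with a stated time of 48 h (on this read-out higher numbers stand for weaker inhibition and lower numbers for stronger inhibition), compound 2 stands highest of the two numbers, with compound 1 nearest. Within the data shown here, the single measured step, a 1.3-fold higher number from compound 1 to compound 2 (0.10 log units; within the scatter), lies within the scatter, so the two compounds cannot be told apart on this read-out.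

Compound 3, `COC(=O)/C=C/c1ccc2c(c1)C(=O)C(=O)N2Cc1ccccc1`, differs from compound 2 by phenyl in place of hydrogen on a saturated chain carbon bound to an amide-type nitrogen in a ring. Among the measured compounds shown here, the only step that bears on it is a 1.3-fold higher number from compound 1 to compound 2 (0.10 log units; within the scatter), which concerns the same amide-type nitrogen in a ring and was within the scatter. For the measured compounds named here, no measured pair adds a phenyl on this chain carbon, so the data give little guidance on the larger group. The expectation is therefore a step of about a 1.2-fold higher number from compound 2 to compound 3 (0.08 log units; within the scatter) in this assay, not beyond the scatter, with a wide range. Compound 3 is estimated at 300 nM, between 120 nM and 800 nM.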

Compound 3, half-maximal inhibitory concentration: 70 nM
Beside the measured number, compound 3's estimate is 4.3-fold (0.63 log units) above it; measured number below the stated range.
By their numbers in this assay, from the lowest: compound 3; then compounds 1 and 2 (each within the scatter of the next).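

In this assay, going from methyl to benzyl on the amide-type nitrogen in a ring gives a 3.6-fold lower number from compound 2 to compound 3 (0.55 log units; beyond the scatter) and so shows that this position can respond to what it carries, which the methyl of compound 2 alone could not show. The comparison with the plain amide hydrogen of compound 1 gives a 2.9-fold lower number from compound 1 to compound 3 (0.46 log units; beyond the scatter) and is also beyond the scatter, so benzyl stands apart from both smaller options, with stronger inhibition. No measurement shown here explains why the phenyl makes this difference.

Going by these compounds, it remains open whether the phenyl ring itself matters or whether a longer chain, such as butyl, would do the same. Also open, on these data alone, is how a phenyl bearing methoxy or chlorine, or a chain ending in an amine, would read.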